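Diethylamino Added to a Coumarin-Linked Triazole Series

The source may hold more compounds than are shown below. What is called first, only, known or untested is meant among the compounds shown, and "the series" means these compounds.

This account concerns four compounds sharing a core in which a coumarin-bearing chain is joined through a triazole to a substituted benzene ring. Compound 1, `O=Cc1ccccc1OCc1cn(CCCOc2ccc3ccc(=O)oc3c2)nn1`, carries a formyl group on that ring; compound 2, `CCN(CC)c1ccc(C=O)c(OCc2cn(CCCOc3ccc4ccc(=O)oc4c3)nn2)c1`, differs from it by diethylamino in place of hydrogen on an aromatic carbon. Compound 3, `NS(=O)(=O)c1ccc(C/N=C/c2ccccc2OCc2cn(CCCOc3ccc4ccc(=O)oc4c3)nn2)cc1`, replaces the formyl group with an imine linked to a sulfonamide-bearing benzyl group; how the core of compound 3 differs from that of compound 1 is not broken down here. Compound 4, `CCN(CC)c1ccc(/C=N/Cc2ccc(S(N)(=O)=O)cc2)c(OCc2cn(CCCOc3ccc4ccc(=O)oc4c3)nn2)c1`, is not yet measured and differs from compound 3 by diethylamino in place of hydrogen on an aromatic carbon.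

In a functional assay on HT-29 cells (Homo sapiens) for cytotoxicity, read by MTT assay, with a stated time of 24 h (on this read-out higher numbers stand for weaker inhibition and lower numbers for stronger inhibition), compound 1 gives 18900 nM, compound 2 gives 9030 nM and compound 3 gives 14300 nM. For the measured compounds named here, the one counted step, a 2.1-fold lower number from compound 1 to compound 2 (0.32 log units; beyond the scatter), is a modest move beyond the scatter. The values of compound 3 and compound 1 lie within the scatter of each other, as do those of compound 3 and compound 2.

The change from compound 3 to compound 4 is the same kind of change as that from compound 1 to compound 2, but the surroundings differ: in compound 2 the entering group sits para to a formyl group, whereas in compound 4 it sits para to a large group. Resting on the step from compound 1 to compound 2, a 2.1-fold lower number from compound 1 to compound 2 (0.32 log units; beyond the scatter), compound 4 is expected to show a step of a 1.9-fold lower number from compound 3 to compound 4 (0.28 log units; within the scatter) in this assay, with the wider range reflecting the different neighbouring group. Compound 4 is therefore estimated at 7500 nM, most likely between 3500 nM and 16000 nM.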

Compound 4, half-maximal inhibitory concentration: 23300 nM
Compound 4: middle estimate off by 3.1-fold (0.49 log units), on the low side; the whole stated range lies below it.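

In this assay, diethylamino in place of hydrogen on an aromatic carbon now gives a 1.6-fold higher number from compound 3 to compound 4 (0.21 log units; within the scatter) and so leaves a difference that cannot be told from repeat measurement. Set beside the earlier step, this shows that the change did not carry over from the core of compound 1 to the core of compound 3 at the size first seen, and that the two steps differ by more than scatter alone would explain: the same change on two cores in this assay, a 2.1-fold lower number (0.32 log units; beyond the scatter) from compound 1 to compound 2 and a 1.6-fold higher number (0.21 log units; within the scatter) from compound 3 to compound 4, 3.4-fold (0.53 log units) apart, beyond the scatter of two such steps. For the compounds shown here, it does not show that diethylamino truly weakens the read-out on the second core, and it gives no reason for the gap, as each core supplies only one pair and the two cores differ by more than a single group.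

The compounds shown leave open whether another amine on the same aromatic carbon, such as dimethylamino or pyrrolidine, would also give different steps on the two cores. They also leave open whether the gap would persist if the sulfonamide were replaced by a carboxylic acid, or if the three-carbon chain to the coumarin were replaced by a longer chain.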